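A few compounds are considered here, and "the series" means these few. Any claim that something is new, unique, unknown or untested is made for them only; others in the source may bear on it.

Measured in a functional assay on MDA-MB-231 cells (Homo sapiens) for antiproliferative activity, read by MTT assay, with a stated time of 72 h; a lower number here means a stronger inhibitor, a higher number a weaker inhibitor:
- compound 1 `CC(C)(C)NC(=O)CCc1cccc2c1B(O)OC2`: > 100000 nM (a limit)
- compound 2 `O=C(CCc1cccc2c1B(O)OC2)Nc1cccc2ccccc12`: 150 nM
- compound 3 `O=C(CCc1cccc2c1B(O)OC2)Nc1cccc(-c2ccccc2)c1`: 220 nM

Compound 1 reaches only the limit of this assay, > 100000 nM (the limit of > 100000 nM in this assay, at which 1 of the 3 values shown sits). Compound 3, at 220 nM, lies within the scatter of compound 2, at 150 nM. Compound 4 `COc1ccc(-c2cccc(NC(=O)CCc3cccc4c3B(O)OC4)c2)cc1` turns the phenyl of compound 3 into 4-methoxyphenyl, with methoxy in place of hydrogen on an aromatic carbon, para to a large group (methoxy in place of hydrogen on an aromatic carbon). Within the data shown here, no measured pair shows this change directly. Since compound 2 at 150 nM and compound 3 at 220 nM sit so close, no shift beyond the scatter is expected in this assay. The expected step, a 1.1-fold higher number from compound 3 to compound 4 (0.06 log units; within the scatter), is estimated to be small. Compound 4 is expected at 250 nM, within an estimated range of 90 nM to 700 nM.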

Compound 4, half-maximal inhibitory concentration: 88 nM
Estimate against measurement, compound 4: 2.8-fold (0.45 log units) above, outside the stated range (below it).
By their numbers in this assay, from the lowest: compounds 4, 2 and 3 (each within the scatter of the next, the first and the last beyond it). At a limit, above all of these: compound 1.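

In this assay, methoxy in place of hydrogen on an aromatic carbon, para to a large group, gives a 2.5-fold lower number from compound 3 to compound 4 (0.40 log units; beyond the scatter). This is the only step shown between compounds differing in one place, and it shows that this position of the phenyl of compound 3 accepts a substituent with a modest gain in this assay. Nothing shown gives a reason for this step. From the compounds shown here alone, what a hydroxyl, an amine or a carboxylic acid would do at this position stays open, and so does whether a longer chain on the oxygen would keep the gain.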